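A few compounds are considered here, and "the series" means these few. Any claim that something is new, unique, unknown or untested is made for them only; others in the source may bear on it.

Of the compounds shown here, three with a shared core have been measured. In a functional assay with Alpha-1B adrenergic receptor (Homo sapiens) as the target, read by calcium flux (on this read-out higher numbers stand for larger maximal responses and lower numbers for smaller maximal responses), compound 1, with the structure `CC(C)n1ncnc1-c1ccccc1NCC1=NCCN1`, gives 0%. Compound 2, with the structure `CCCn1nccc1-c1ccccc1NCC1=NCCN1`, gives 0% in this assay, and compound 3, with the structure `CCn1cccc1-c1ccccc1NCC1=NCCN1`, gives 0%. On these numbers compound 2 stands level with compound 1 and with compound 3: none of the three produces any response at the digits shown, and the gaps between them lie within the scatter, so no order among them can be drawn.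

Compound 4, with the structure `Cn1nccc1-c1ccccc1NCC1=NCCN1`, has not yet been measured. Compared with compound 2 it carries a single change: hydrogen in place of ethyl on a saturated chain carbon bound to an aromatic nitrogen. Because compound 2 gives 0%, and its neighbours with other groups in the same place are equally silent, the step of no change at the digits printed from compound 2 to compound 4 (within the scatter) is expected to stay within the scatter rather than move in either direction. Compound 4 is therefore estimated to give 0% in this assay, with a range from 0% to 8%.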

Compound 4, largest response reached (reported as maximal response), in percent of the reference or control that the assay uses: 0%
Compound 4: the middle estimate sits on the measured number at the digits printed; low and high end bracket the measured number.
By their numbers in this assay, from the lowest: compounds 1, 2, 3 and 4 (each within the scatter of the next).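

In this assay, replacing ethyl with hydrogen on a saturated chain carbon bound to an aromatic nitrogen, which reads as propyl to methyl, gives no change at the digits printed from compound 2 to compound 4 (within the scatter). Within the data shown here, this is the first comparison here in which only one place differs, and it shows that cutting this chain down to methyl does not bring out a response on the shared core, although a step between two silent compounds says little about how much the chain matters. No measurement shown here offers an explanation for this silence.

The compounds shown leave open whether a longer chain such as hexyl, or an amine or a carboxylic acid in place of the ethyl, would give any response. They also leave open whether this position affects the response at all.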